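This account rests on a few compounds, and the source may have more. Where it says the series, first, only, none or still open, it means among the compounds named here.

Compound 1 `NS(=O)(=O)CC(=O)NCCSc1nonc1/C(=N/O)Nc1cccc(Cl)c1`: > 3 h (a limit)
Compound 2 `NS(=O)(=O)CC(=O)NCCSc1nonc1/C(=N/O)Nc1ccc(F)c(C(F)F)c1`: 2.77 h
Compound 3 `NS(=O)(=O)CC(=O)NCCSc1nonc1/C(=N/O)Nc1cccc(Br)c1`: > 3 h (a limit)

In an ADME assay on microsomes from liver (Homo sapiens) for metabolic stability (on this read-out higher numbers stand for a longer-lived compound and lower numbers for a shorter-lived compound), compound 3 gives > 3 h, which is a limit of the assay and not a number. The ceiling here is the limit of > 3 h in this assay, at which 2 of the 3 values shown sit. Compound 4 `N#Cc1cc(N/C(=N\O)c2nonc2SCCNC(=O)CS(N)(=O)=O)ccc1F` carries 3-cyano-4-fluorophenyl in place of 3-bromophenyl on an amine nitrogen. Compound 2, with its 3-(difluoromethyl)-4-fluorophenyl, offers the nearest comparison. The measured swaps on this nitrogen are an at least 1.0-fold higher number from compound 2 to compound 3 (0.03 log units; that floor lies within the scatter) and an at least 1.0-fold lower number from compound 1 to compound 2 (0.03 log units; that floor lies within the scatter). The remaining one, a step that the two limits leave unreadable from compound 1 to compound 3, cannot be sized. Neither readable swap shows a change beyond the scatter, so none is expected here. The expected step is an at least 1.0-fold lower number from compound 3 to compound 4 (0.02 log units; that floor lies within the scatter). Compound 4 is estimated at 2.8 h, with an expected range of 1.6 h to 4.5 h.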

Compound 4, half-life: > 3 h
Compound 4 ended at the assay's limit; the forecaster's own chance of this, stated with the estimate: 50%; at least 1.0-fold (0.02 log units) between middle value and limit.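

A nitrile-bearing ring on this amine nitrogen now also gives a limit rather than a number, as the 3-chlorophenyl and 3-bromophenyl rings did. Replacing difluoromethyl with cyano on an aromatic carbon gives, in this assay, an at least 1.0-fold higher number from compound 2 to compound 4 (0.03 log units; that floor lies within the scatter). The steps to compound 4 from compound 1 and compound 3 cannot be read, because these values crowd at the ceiling: the limit of > 3 h in this assay, at which 3 of the 4 values shown sit.

As far as these compounds go, how far these compounds differ beyond that ceiling remains open. So does whether an amine or a carboxylic acid on this phenyl ring would give a value clearly lower in this assay.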